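Oxadiazole to Thiadiazole: One Ring Swap in a Growth Inhibitor

The compounds below may be only part of what the source reports. "The series", "measured", "known", "first", "only" and "open" are said of these compounds alone.

Compound 1 `COc1cc(CSc2cc(Cl)c(-c3nc(-c4ccc(Cl)cc4)no3)cc2S(=O)(=O)NC(=N)NO)cc(OC)c1OC` was tested in a functional assay on M14 cells (Homo sapiens) (a higher number here means a weaker inhibitor of growth, a lower number a stronger inhibitor of growth), where compound 1 gives 2190 nM. Its companion compound 2 `N=C(NO)NS(=O)(=O)c1cc(-c2nc(-c3ccccc3)no2)c(Cl)cc1SCc1ccccc1` gives 2150 nM in this assay, a value that sits within the usual scatter of compound 1, so the two cannot be told apart. Compound 3 `COc1cc(CSc2cc(Cl)c(-c3nnc(-c4ccc(Cl)cc4)s3)cc2S(=O)(=O)NC(=N)NO)cc(OC)c1OC` has not yet been measured. It differs from compound 1 in one place: 5-(4-chlorophenyl)-1,3,4-thiadiazol-2-yl in place of 3-(4-chlorophenyl)-1,2,4-oxadiazol-5-yl on an aromatic carbon. Among the compounds with values here, no measured pair shows what this change does. The step from compound 1 to compound 3 is expected to be small, about a 1.1-fold lower number from compound 1 to compound 3 (0.04 log units; within the scatter), in no clear direction. Compound 3 is thus estimated at 2000 nM, between 800 nM and 5000 nM.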

Compound 3, concentration for 50% growth inhibition: 40700 nM
Compound 3: middle estimate off by 20-fold (1.31 log units), on the low side; measured number outside the range, above it.
By their numbers in this assay, from the lowest: compounds 2 and 1 (each within the scatter of the next); then compound 3.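

In this assay the ring swap gives a 19-fold higher number from compound 1 to compound 3 (1.27 log units; beyond the scatter) and so a much weaker inhibitor of growth. This position is therefore sensitive to the ring it carries: the two groups have the same counts of heavy atoms, hydrogen-bond donors and acceptors, yet they do not perform alike. No measurement here explains the loss. The swap replaces oxygen with sulfur and also rearranges the ring atoms, so the effect of each remains unseparated. A 5-(4-chlorophenyl)-1,3,4-oxadiazol-2-yl group would be needed to tell them apart.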